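A Dichlorophenyl Swap in a Level Cytotoxicity Series

This account rests on a few compounds, and the source may have more. Where it says the series, first, only, none or still open, it means among the compounds named here.

Of the compounds shown here, three sharing one core have been measured in a functional assay on SW-620 cells (Homo sapiens) for cytotoxicity, read by MTT assay, with a stated time of 72 h; a higher number here means a weaker inhibitor, a lower number a stronger inhibitor. Compound 1 `COc1ccc(/C=C2\CCC/C(=C\c3ccccc3Br)C2=O)cc1OC` gives 5300 nM, compound 2 `COc1ccc(/C=C2\CCC/C(=C\c3ccc(Br)cc3)C2=O)cc1OC` gives 5200 nM and compound 3 `COc1ccc(/C=C2\CCC/C(=C\c3ccc(OC)c(OC)c3)C2=O)cc1` gives 6600 nM. The gaps from compound 3 to the other two lie within the scatter, so it stands level with them.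

The next compound, compound 4 `COc1ccc(/C=C2\CCC/C(=C\c3ccc(Cl)cc3Cl)C2=O)cc1OC`, differs from compound 3 on a double-bonded chain carbon bound to a double-bonded ring carbon: 2,4-dichlorophenyl in place of 4-methoxyphenyl on a double-bonded chain carbon bound to a double-bonded ring carbon. For the measured compounds named here, three measured steps bear on this exchange. Moving the bromo group gave a 1.0-fold lower number from compound 1 to compound 2 (0.01 log units; within the scatter). Replacing a bromophenyl group gave a 1.2-fold higher number from compound 1 to compound 3 (0.10 log units; within the scatter), and methoxy in place of bromo gave a 1.3-fold higher number from compound 2 to compound 3 (0.10 log units; within the scatter). All three lie within the scatter, so the aryl groups tried so far have left the number in this assay essentially unmoved. Going by the values given here, no measured compound carries chlorine, however, and none has the 2,4-dichlorophenyl group, so the data cannot test this group directly.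

No change beyond the scatter is therefore expected, and the estimate is a 1.3-fold lower number from compound 3 to compound 4 (0.12 log units; within the scatter). Compound 4 is expected to give about 5000 nM, with an estimated range from 2500 nM to 9500 nM.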

Compound 4, half-maximal inhibitory concentration: 10300 nM
Estimate against measurement, compound 4: 2.1-fold (0.31 log units) below; the measured number lies above the stated range.
By their numbers in this assay, from the lowest: compounds 2, 1, 3 and 4 (each within the scatter of the next).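

For the compounds shown here, at the double-bonded chain carbon bound to a double-bonded ring carbon, the 2,4-dichlorophenyl group is the only group here that carries chlorine, and in this assay it stands level with all three earlier aryl groups: the exchange gives a 1.6-fold higher number from compound 3 to compound 4 (0.19 log units; within the scatter), while the comparisons with the two bromophenyl compounds give a 2.0-fold higher number from compound 2 to compound 4 (0.30 log units; within the scatter) and a 1.9-fold higher number from compound 1 to compound 4 (0.29 log units; within the scatter). Going by these compounds alone, these are the largest steps so far, yet each remains within the scatter, so the four compounds show no measurable effect of the aryl group at this place, now across bromo, methoxy and chloro groups, including two chlorines on one ring. No evidence is available to explain where the number for compound 4 sits.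

Every group shown at this place is a phenyl ring bearing bromo, methoxy or chloro, so it remains open whether an amine, a carboxylic acid or a longer chain there would move the number beyond the scatter. Going by these compounds, it also remains open whether a phenyl ring with a single chlorine would stand level with these four compounds.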